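Nitro in place of a carbamate on the indazole core

The source may report more compounds than this note shows. Statements on the series, on what has been measured and on what is new or still open speak of the compounds shown alone.

Measured so far:
compound 1 `O=C(COc1ccc(Oc2ccccc2)cc1)Cn1ncc2cc(C(=O)O)ccc21` gives 55 nM
compound 2 `CC(=O)Nc1ccc2c(cnn2CC(=O)COc2ccc(Oc3ccccc3)cc2)c1` gives 3900 nM
compound 3 `COC(=O)Nc1ccc2c(cnn2CC(=O)COc2ccc(Oc3ccccc3)cc2)c1` gives 4000 nM

In an assay on microsomes from brain for inhibition of Fatty-acid amide hydrolase 1 (Rattus norvegicus), read by fluorescence and HPLC, with a stated time of 45 min (on this read-out higher numbers stand for weaker inhibition and lower numbers for stronger inhibition), compound 3 stands at the highest of the three numbers; compound 2 sits within the scatter of it, while compound 1 lies far below, a gap of a 73-fold higher number from compound 1 to compound 3 (1.86 log units; beyond the scatter). Compound 4 `O=C(COc1ccc(Oc2ccccc2)cc1)Cn1ncc2cc([N+](=O)[O-])ccc21` differs from compound 3 by nitro in place of (methoxycarbonyl)amino on an aromatic carbon. Among the measured compounds shown here, no measured step covers this exact change; the steps that bear on it are a 71-fold higher number from compound 1 to compound 2 (1.85 log units; beyond the scatter) and a 73-fold higher number from compound 1 to compound 3 (1.86 log units; beyond the scatter), both large and both at this same aromatic carbon, whereas the step of a 1.0-fold higher number from compound 2 to compound 3 (0.01 log units; within the scatter) stays within the scatter. Since the measured changes at this position were large, a sizeable step is plausible but its direction is uncertain; the estimate for compound 4 is 1500 nM (range 300 nM to 7000 nM), a step of a 2.7-fold lower number from compound 3 to compound 4 (0.43 log units; beyond the scatter).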

Compound 4, half-maximal inhibitory concentration: 550 nM
Beside the measured number, compound 4's estimate is 2.7-fold (0.44 log units) above it; the range from low to high includes it.
By their numbers in this assay, from the lowest: compound 1; then compound 4; then compounds 2 and 3 (each within the scatter of the next).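

In this assay nitro separates itself from both amide-type groups at this aromatic carbon (a 7.3-fold lower number from compound 3 to compound 4 (0.86 log units; beyond the scatter); a 7.1-fold lower number from compound 2 to compound 4 (0.85 log units; beyond the scatter)) but does not match carboxy (a 10-fold higher number from compound 1 to compound 4 (1.00 log units; beyond the scatter)). The earlier compounds shown here showed only carboxy and two groups within the scatter of each other, while compound 4 adds an intermediate level, so groups at this carbon do not fall into just two levels. Nothing available accounts for this order. As far as these compounds go, how an amine or a methyl ester at this carbon would compare stays open. So does whether a longer chain carrying the carboxy would keep the level of compound 1.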